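Piperidin-1-yl for diisopropylamino: cytotoxicity working notes

The compounds below may be only part of what the source reports. "The series", "measured", "known", "first", "only" and "open" are said of these compounds alone.

Measured in a functional assay on A549 cells (Homo sapiens) for cytotoxicity, read by MTT assay, with stated times of 48 h and 4 h (a lower number here means a stronger inhibitor, a higher number a weaker inhibitor), so far:
- Compound 1 `COc1ccc(/C=C/c2nc(NCCN3CCCCC3)c3ccccc3n2)cc1OC` gives 82700 nM (a number)
- Compound 2 `COc1ccc(/C=C/c2nc(NCCN(C(C)C)C(C)C)c3cc(Cl)ccc3n2)cc1OC` gives > 100000 nM (a limit)

For compound 2, this assay reports only a limit (> 100000 nM), not a number.

Compound 3 `COc1ccc(/C=C/c2nc(NCCN3CCCCC3)c3cc(Cl)ccc3n2)cc1OC` is unmeasured. It carries piperidin-1-yl in place of diisopropylamino on a saturated chain carbon, two bonds along the chain from a nitrogen on an aromatic ring. No measured step sizes this change. Compound 1 also carries piperidin-1-yl and gives a number (82700 nM), so a small shift towards lower values in this assay is expected. The expected size is an at least 1.4-fold lower number from compound 2 to compound 3 (0.15 log units; that floor lies within the scatter) and it may prove no larger than the scatter. Compound 3 is estimated at 70000 nM (expected range 30000 nM to 100000 nM).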

Compound 3, half-maximal inhibitory concentration: > 100000 nM
Compound 3: no number, only a limit; the forecaster's own chance of this, stated with the estimate: 35%; at least 1.4-fold (0.15 log units) between middle value and limit.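

Chloro in place of hydrogen on an aromatic carbon, a change no earlier pair isolated, gives in this assay an at least 1.2-fold higher number from compound 1 to compound 3 (0.08 log units; that floor lies within the scatter). The step from diisopropylamino to piperidin-1-yl on a saturated chain carbon cannot be read because compound 2 and compound 3 both end at a limit: the limit of > 100000 nM in this assay, at which 2 of the 3 values shown sit.

As far as these compounds go, whether piperidin-1-yl and diisopropylamino differ at all with chloro present stays open. Also open, from the compounds shown here alone, is whether morpholin-4-yl, dimethylamino or a longer chain in that place would bring the chloro series to a number.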